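Fluoro for hydrogen on the benzyl group of compound 3

A few compounds are considered here, and "the series" means these few. Any claim that something is new, unique, unknown or untested is made for them only; others in the source may bear on it.

Measured compounds:
compound 2 `N#Cc1c(NCc2ccc(F)cc2)sc2c1CCN(C(=O)c1ccn[nH]1)C2` gives 2030 nM
compound 3 `N#Cc1c(NCc2ccccc2)sc2c1CCN(C(=O)c1ccccc1)C2` gives 2820 nM

Compound 1 `CC(C)c1cc(C(=O)N2CCc3c(sc(NCc4ccc(F)cc4)c3C#N)C2)[nH]n1` stands in a functional assay on Chem-3 cells for antagonist activity at metabotropic glutamate receptor 1 (Homo sapiens), read by fluorescence and calcium flux (on this read-out higher numbers stand for weaker inhibition and lower numbers for stronger inhibition), as "not determined" (no result reported), so it has no reported result there. Of the two numbers in this assay, compound 3 has the higher one, but its gap to compound 2 lies within the usual scatter, so the two stand together. Within the data shown here, compound 4 `N#Cc1c(NCc2ccc(F)cc2)sc2c1CCN(C(=O)c1ccccc1)C2` differs from compound 3 in one place: fluoro in place of hydrogen on an aromatic carbon No measured pair in this set shows this exact difference, and compound 2, which carries the same 4-fluorobenzyl, differs from compound 3 in a second place as well. The step from compound 3 to compound 4 is therefore expected to be small, a 1.2-fold lower number from compound 3 to compound 4 (0.09 log units; within the scatter), not beyond the scatter. Compound 4 is estimated at 2300 nM, with a range of 900 nM to 6000 nM.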

Compound 4, half-maximal inhibitory concentration: 1810 nM
The estimate for compound 4 lay 1.3-fold (0.10 log units) above the measured number, within the range that was stated.
By their numbers in this assay, from the lowest: compounds 4, 2 and 3 (each within the scatter of the next).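

The matched pair shows that, in this assay, benzyl and 4-fluorobenzyl are not told apart, with fluoro in place of hydrogen giving only a step within the scatter (a 1.6-fold lower number from compound 3 to compound 4 (0.19 log units; within the scatter)). With the 4-fluorobenzyl kept, phenyl in place of 1H-pyrazol-5-yl on the carbonyl carbon also stays within the scatter (a 1.1-fold lower number from compound 2 to compound 4 (0.05 log units; within the scatter)). No measurement bears on why these steps are small.

From the compounds shown here alone, what a chloro, a methoxy or an amine on that aromatic carbon would give remains open. Compound 1 has no reported result, leaving the effect of a substituent on the 1H-pyrazol-5-yl group unread.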